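Acyl chain length in the cytidine-amide series

The source may hold more compounds than are shown below. What is called first, only, known or untested is meant among the compounds shown, and "the series" means these compounds.

Measured compounds in a functional assay on HL-60 cells (Homo sapiens) for cytotoxicity, read by MTT assay, with a stated time of 48 h; on this read-out lower numbers stand for stronger inhibition and higher numbers for weaker inhibition:
Compound 1 `CCCCCCCCCCCCCC(=O)N[C@@H](CCC(=O)O)C(=O)Nc1ccn([C@H]2O[C@@H](CO)[C@H](O)[C@H]2O)c(=O)n1`: 502 nM
Compound 2 `CCCCCCCCCC(=O)N[C@@H](CCCNC(=N)N)C(=O)Nc1ccn([C@H]2O[C@@H](CO)[C@H](O)[C@H]2O)c(=O)n1`: 584 nM
Compound 3 `CCCCCCCCCCCCCC(=O)N[C@H](C(=O)Nc1ccn([C@H]2O[C@@H](CO)[C@H](O)[C@H]2O)c(=O)n1)C(C)C`: 32300 nM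

Compound 1 gives the lowest of the three numbers; compound 2 lies within the scatter of it, so no order between the two can be read, while compound 3 sits far higher. Going by the values given here, the one single-place step in the set, a 64-fold higher number from compound 1 to compound 3 (1.81 log units; beyond the scatter), concerns the side chain on the carbon bound to the amide-type nitrogen and the carbonyl carbon, not the acyl chain.

Compound 4 `CCCCCCCCCCCCCCCCCC(=O)N[C@@H](CCC(=O)O)C(=O)Nc1ccn([C@H]2O[C@@H](CO)[C@H](O)[C@H]2O)c(=O)n1` differs from compound 1 only at the far end of the acyl chain: butyl in place of hydrogen on a saturated chain carbon, ten or more bonds along the chain from a carbonyl carbon. Among the compounds with values here, no measured step touches this position. Compound 2 carries a shorter acyl chain than compound 1 and a different side chain as well, and its number is within the scatter of compound 1, so the two values together give no sign that acyl chain length alone moves this read-out. The expectation is therefore a step of a 1.2-fold higher number from compound 1 to compound 4 (0.08 log units; within the scatter), that is, nothing beyond the scatter in either direction. Compound 4 is expected to give about 600 nM, estimated between 250 nM and 1500 nM.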

Compound 4, half-maximal inhibitory concentration in the HL-60 assay: 1140 nM
Compound 4: the middle estimate sits 1.9-fold (0.28 log units) below what was measured; the measured number falls inside the stated range.
By their numbers in the HL-60 assay, from the lowest: compounds 1, 2 and 4 (each within the scatter of the next, the first and the last beyond it); then compound 3.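

Butyl in place of hydrogen on a saturated chain carbon is not silent in the HL-60 assay: this position now has its first measured step, a 2.3-fold higher number from compound 1 to compound 4 (0.36 log units; beyond the scatter), a modest one. In a physicochemical assay for lipophilicity (on this read-out higher numbers stand for higher lipophilicity and lower numbers for lower lipophilicity), compound 1 gives 0.25 and compound 4 gives 0.5, so the same change reads as a number 0.25 log units higher from compound 1 to compound 4 (within the scatter). Nothing available gives a reason for the step in cell cytotoxicity.

As far as these compounds go, with a single step at this position, it remains open whether a longer chain would carry the direction further or a shorter chain on the 2-carboxyethyl side chain would reverse it. Also open, from the compounds shown here alone, are the effect of an amine or a carboxylic acid at this position and whether butyl acts alike with the isopropyl side chain of compound 3.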